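This account rests on a few compounds, and the source may have more. Where it says the series, first, only, none or still open, it means among the compounds named here.

Working notes on the series.

Compound 3 `CC(C)C/N=C(\NC#N)Nc1cccnc1` gives 20 mg/kg in a functional assay on the whole organism (blood, strain Wistar-Okamoto) with Rattus norvegicus as the target, with a stated time of 5 days; a lower number here means that less compound is needed, a higher number that more compound is needed for the effect. Compound 2 `CCCC/N=C(\NC#N)Nc1cccnc1` gives 20 mg/kg, and the two stand level at the digits shown, so compound 3 sits with compound 2 and no order between them can be read. Compound 1 `C/N=C(\NC#N)Nc1cccnc1` gives only a limit of the assay, > 50 mg/kg, so its position is known only as a bound.

Compound 4 `CCCCCCC/N=C(\NC#N)Nc1cccnc1` is unmeasured. It differs from compound 3 as follows: hexyl in place of isopropyl on a saturated chain carbon bound to a double-bonded nitrogen.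

Steps that bear on a change at this position: an at least 2.5-fold lower number from compound 1 to compound 2 (0.39 log units; beyond the scatter), an at least 2.5-fold lower number from compound 1 to compound 3 (0.39 log units; beyond the scatter), and no change at the digits printed from compound 2 to compound 3 (within the scatter). The two steps away from hydrogen are bounded by the limit (the limit of > 50 mg/kg in this assay, at which 1 of the 3 values shown sits), so only their minimum size is known. The step from propyl to isopropyl shows no change, so the shape of the chain at this carbon has not mattered within the range covered; a longer chain lies outside it.

The expected step is therefore a 1.3-fold lower number from compound 3 to compound 4 (0.12 log units; within the scatter), with the hexyl carrying the series into untested length. Compound 4 is estimated at 15 mg/kg, with a range from 5 mg/kg to 50 mg/kg.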

Compound 4, minimum effective dose: > 50 mg/kg
Compound 4 gave a limit, no number (the forecaster's own chance of this, stated with the estimate: 15%); at least 3.3-fold (0.52 log units) between middle value and limit.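

In this assay, hexyl in place of isopropyl gives an at least 2.5-fold higher number from compound 3 to compound 4 (0.39 log units; beyond the scatter), and the longer chain of compound 4 set against compound 2 gives an at least 2.5-fold higher number from compound 2 to compound 4 (0.39 log units; beyond the scatter), so the gain seen on leaving hydrogen does not extend to every longer chain at this position. Across these four compounds, the number is lower only for compound 2 and compound 3, while the shortest chain, in compound 1, and the longest, in compound 4, both end at a limit rather than a number. The step between compound 1 and compound 4 cannot be read, and the size of each readable step to compound 4 is known only as a minimum: the limit of > 50 mg/kg in this assay, at which 2 of the 4 values shown sit.

Where the number starts to rise along the chain, between compound 2 and compound 4, remains open. Also open, on these data alone, is whether a pentyl chain, or a chain of this length ending in an amine, would keep the lower number.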